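Aryl in Place of Methyl on the Ring Amide Nitrogen

A few compounds are considered here, and "the series" means these few. Any claim that something is new, unique, unknown or untested is made for them only; others in the source may bear on it.

Among the measured compounds shown here, compound 1 `CC(C)[C@@H]1CC[C@@H](C)C[C@@]12N(C)C(=O)[C@@H]1[C@H]3C(=O)N(C)C(=O)[C@H]3ON12` gives 43.1% in a functional assay, with a stated time of 20 min, tested at 1 mg/mL (a higher number here means a stronger effect of the compound at the concentration tested, a lower number a weaker effect), and stands lowest of the two numbers measured so far. Compound 2 `CC(C)[C@@H]1CC[C@@H](C)C[C@@]12N(C)C(=O)[C@@H]1[C@H]3C(=O)N(c4ccccc4)C(=O)[C@H]3ON12` gives 54.9% in this assay. Compound 3 `COc1ccc(N2C(=O)[C@H]3[C@H](ON4[C@@H]3C(=O)N(C)[C@@]43C[C@H](C)CC[C@H]3C(C)C)C2=O)cc1` has not yet been measured. It differs from compound 1 by 4-methoxyphenyl in place of methyl on an amide-type nitrogen in a ring. For the measured compounds named here, the one measured step that bears on this change is the exchange of phenyl for methyl on the same amide-type nitrogen in a ring, a number 11.8 percentage points higher from compound 1 to compound 2 (beyond the scatter), a modest rise beyond the scatter. The 4-methoxyphenyl of compound 3 is a related aromatic replacement, so a rise of about that size is expected; no measured point shows whether the methoxy adds to it or takes from it. Compound 3 is therefore expected to give about 55% in this assay, within a range from 40% to 70%. This estimate means an expected step of a number 11.9 percentage points higher from compound 1 to compound 3 (beyond the scatter).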

Compound 3, a percentage reported as activity, at one concentration (the size of the read-out at that concentration, not a potency): 48.1%
Beside the measured number, compound 3's estimate is 6.9 percentage points above it; the measured number falls inside the stated range.
By their numbers in this assay, from the lowest: compounds 1, 3 and 2 (each within the scatter of the next, the first and the last beyond it).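

In this assay, 4-methoxyphenyl in place of methyl on the amide-type nitrogen gives a number 5 percentage points higher from compound 1 to compound 3 (within the scatter), so this aromatic replacement, unlike phenyl with a number 11.8 percentage points higher from compound 1 to compound 2 (beyond the scatter), does not clear the scatter relative to compound 1. Methoxy in place of hydrogen on an aromatic carbon gives a number 6.8 percentage points lower from compound 2 to compound 3 (within the scatter), which leaves compound 3 unresolved from both compound 1 and compound 2, and the position tolerates this aryl group without showing any clear effect of the methoxy. No measurement here accounts for these numbers.

As far as these compounds go, whether an amine or a carboxylic acid in place of the methoxy would separate from compound 2 remains open. Also open, from the compounds shown here alone, is whether a longer chain, such as butyl, in place of methyl on the same nitrogen would match phenyl or stay with methyl.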